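A few compounds are considered here, and "the series" means these few. Any claim that something is new, unique, unknown or untested is made for them only; others in the source may bear on it.

Measured so far:
- compound 1 `CN(CC1CCC/C(=C\c2ccccc2)C1=O)c1ccccc1`: 69.7%
- compound 2 `Cc1cccc(N(C)CC2CCC/C(=C\c3ccccc3)C2=O)c1`: 76.7%

In a functional assay on the whole organism (strain Kunming) for inhibition, with Mus musculus as the target, in the writhing test, with stated times of 1 h and 15 min, at a dose of 200 mg/kg by the oral route (a lower number here means less inhibition, a higher number more inhibition at the dose given (going by the name of the read-out)), compound 1 gives 69.7%, the lowest of the two numbers shown, although its nearest neighbour compound 2, which gives 76.7%, sits within the usual scatter, so the two cannot be ranked. Among the measured compounds shown here, the one measured step, a number 7 percentage points higher from compound 1 to compound 2 (within the scatter), is the change of methyl in place of hydrogen on an aromatic carbon.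

Compound 3 `CN(CC1CCC/C(=C\c2ccc(S(C)(=O)=O)cc2)C1=O)c1ccccc1` is not yet measured. It differs from compound 1 by methylsulfonyl in place of hydrogen on an aromatic carbon. For the measured compounds named here, no measured step touches this part of the structure; the only step known, from compound 1 to compound 2, changes a different ring and stayed within the scatter. There is therefore no basis to expect a step beyond the scatter in this assay, in either direction.

Compound 3 is thus estimated at 68%, within 50% to 85%, which means an expected step of a number 1.7 percentage points lower from compound 1 to compound 3 (within the scatter).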

Compound 3, a percentage reported as inhibition, in the whole organism at one dose (the size of the read-out at that dose, not a potency): 81%
Compound 3: the middle estimate sits 13 percentage points below what was measured; the range from low to high includes it.
By their numbers in this assay, from the lowest: compounds 1, 2 and 3 (each within the scatter of the next, the first and the last beyond it).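

In this assay, methylsulfonyl in place of hydrogen on an aromatic carbon, para to a large group, gives a number 11.3 percentage points higher from compound 1 to compound 3 (beyond the scatter) and is the first change shown to lie beyond the scatter, though only modestly. Among the compounds shown here, this shows that the core of compound 1 can carry a group of 4 heavy atoms at this carbon without losing inhibition at this dose, on a different ring from the one changed in compound 2. Nothing measured here explains the rise.

From the compounds shown here alone, whether the gain is specific to methylsulfonyl remains open, since a methyl, a methoxy, a chlorine or a carboxylic acid on the same carbon would test how far it extends to other groups. A single dose also leaves open how the compounds compare in potency.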